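Sulfamoyl ureas and carbamates on a shared diisopropylphenyl core

This account rests on a few compounds, and the source may have more. Where it says the series, first, only, none or still open, it means among the compounds named here.

Measured so far:
compound 1 `C=CCN(CC)S(=O)(=O)NC(=O)Nc1c(C(C)C)cccc1C(C)C` — 2100 nM
compound 2 `CC(C)c1cccc(C(C)C)c1NS(=O)(=O)NC(=O)N(Cc1ccccc1)Cc1ccccc1` — 16000 nM
compound 3 `CC(C)c1cccc(C(C)C)c1OC(=O)NS(=O)(=O)N1CCCC1` — 53000 nM

In an assay on liver for inhibition of sterol O-acyltransferase 1 (Rattus norvegicus), using microsomes (a higher number here means a weaker inhibitor, a lower number a stronger inhibitor), compound 3 gives the highest number of the three, with the gap to compound 2 the smallest and the gap to compound 1 the largest, both gaps beyond the scatter. Compound 4 `CC(C)c1cccc(C(C)C)c1OC(=O)NS(=O)(=O)N(C(C)C)C(C)C` differs from compound 3 in one place: diisopropylamino in place of pyrrolidin-1-yl on a sulfonyl sulfur. Within the data shown here, no step between two measured compounds isolates this change, so the expectation for this assay rests on the position of compound 3 alone. A step toward a lower number is expected from compound 3 to compound 4, of size a 2.1-fold lower number from compound 3 to compound 4 (0.33 log units; beyond the scatter), and it may fall within the scatter. Compound 4 is estimated at 25000 nM in this assay, with a range of 6000 nM to 100000 nM.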

Compound 4, half-maximal inhibitory concentration: 15000 nM
For compound 4 the middle estimate is 1.7-fold (0.22 log units) above the measured one; low and high end bracket the measured number.
By their numbers in this assay, from the lowest: compound 1; then compounds 4 and 2 (each within the scatter of the next); then compound 3.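

In this assay the sulfonyl sulfur of the carbamate series proves sensitive to the amino group it carries, giving a step of a 3.5-fold lower number from compound 3 to compound 4 (0.55 log units; beyond the scatter) when open-chain diisopropylamino replaces the ring of pyrrolidin-1-yl. Among these compounds, this is the first single-place comparison, and the step is modest and beyond the scatter. Nothing measured here accounts for the shift.
On these data alone, whether dimethylamino or a longer chain such as dibutylamino would continue this step stays open. So does whether the same exchange on the sulfamoyl urea of compound 1 would move the number similarly.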